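Oxidising one sulfur in a dithioacetal leukotriene ligand

A few compounds are considered here, and "the series" means these few. Any claim that something is new, unique, unknown or untested is made for them only; others in the source may bear on it.

Compound 1 `CCCCCCCCCCCCc1ccccc1C(SCCC(=O)O)SCCC(=O)O` gives the lowest number of the two measured in an assay on membranes from lung (Cavia porcellus) for binding affinity to cysteinyl leukotriene receptor (Homo sapiens) (on this read-out lower numbers stand for stronger inhibition and higher numbers for weaker inhibition), namely 445 nM. Compound 2 `O=C(O)CCSC(SCCC(=O)O)c1ccccc1CCCCCCCCC1CCCCC1` gives 1960 nM, and the step of a 4.4-fold higher number from compound 1 to compound 2 (0.64 log units; beyond the scatter) concerns the chain far from the central carbon. Compound 3 `CCCCCCCCCCCCc1ccccc1C(SCCC(=O)O)[S+]([O-])CCC(=O)O` differs from compound 1 by a group of 7 heavy atoms (3 carbon, 3 oxygen, 1 sulfur; no ring) in place of a group of 6 heavy atoms (3 carbon, 2 oxygen, 1 sulfur; no ring), on a saturated chain carbon bound to an aromatic carbon and a sulfur. Among the measured compounds shown here, no measured step touches this place, so the only guide is the modest size of the one known change; a small to modest weakening is expected, with the estimated step being a 2.0-fold higher number from compound 1 to compound 3 (0.31 log units; beyond the scatter). Compound 3 is thus expected to give 900 nM, within 300 nM to 3000 nM.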

Compound 3, inhibition constant: 423 nM
For compound 3 the middle estimate is 2.1-fold (0.33 log units) above the measured one; measured number inside the range.
By their numbers in this assay, from the lowest: compounds 3 and 1 (each within the scatter of the next); then compound 2.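

Among the compounds shown here, at the saturated chain carbon bound to an aromatic carbon and a sulfur, the earlier compounds showed nothing. Here, in this assay, exchanging (2-carboxyethyl)sulfanyl for the group with one extra oxygen on its sulfur gives a 1.1-fold lower number from compound 1 to compound 3 (0.02 log units; within the scatter), so this exchange is tolerated on this read-out. No available measurement bears on this result. Still open, as far as these compounds go, is whether a sulfone at this sulfur, carrying two oxygens, would be tolerated as well. Equally open, from the compounds shown here alone, is whether the same extra oxygen on the other sulfur would be.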